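Removing a chloro from a weak trimethoxyphenyl triazole series

A few compounds are considered here, and "the series" means these few. Any claim that something is new, unique, unknown or untested is made for them only; others in the source may bear on it.

Measured compounds:
- compound 1, `COc1cc(-c2nnc3n2NC(c2ccco2)C(C(=O)c2cccs2)S3)cc(OC)c1OC`: 46200 nM
- compound 2, `COc1cc(-c2nnc3n2NC(c2ccco2)C(C(=O)c2ccc(Cl)cc2)S3)cc(OC)c1OC`: 67800 nM

Both compounds were tested in a functional assay on PC-3 cells (Homo sapiens) for cytotoxicity, read by MTT assay, with a stated time of 48 h; a lower number here means a stronger inhibitor, a higher number a weaker inhibitor. Compound 1 gives 46200 nM, and compound 2 gives 67800 nM, the higher of the two numbers, though the step of a 1.5-fold higher number from compound 1 to compound 2 (0.17 log units; within the scatter) lies within the scatter, so the two cannot be told apart. The only difference between them is a 4-chlorophenyl in place of thiophen-2-yl on the carbonyl carbon.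

Compound 3, `COc1cc(-c2nnc3n2NC(c2ccco2)C(C(=O)c2ccccc2)S3)cc(OC)c1OC`, has not been measured. It differs from compound 2 by hydrogen in place of chloro on an aromatic carbon. For the measured compounds named here, no measured step removes a chloro from this ring, so the closest guide is the swap on the carbonyl carbon from compound 1 to compound 2, which changed little. Trimming a single chlorine from the benzoyl group is a small change in a series where both measured numbers are high, so no step beyond the scatter is expected in this assay, in either direction.

The estimate for compound 3 is therefore 60000 nM, with a range from 25000 nM to 150000 nM, an expected step of a 1.1-fold lower number from compound 2 to compound 3 (0.05 log units; within the scatter).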

Compound 3, half-maximal inhibitory concentration: 64300 nM
The estimate for compound 3 lay 1.1-fold (0.03 log units) below the measured number, and the stated range covers the measured number.
By their numbers in this assay, from the lowest: compounds 1, 3 and 2 (each within the scatter of the next).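

In this assay, hydrogen in place of chloro gives a 1.1-fold lower number from compound 2 to compound 3 (0.02 log units; within the scatter), so on this aromatic carbon, para to a large group, the chloro and the hydrogen cannot be told apart. Compound 3 also offers a cleaner comparison of the two groups on the carbonyl carbon than the earlier pair did, since its phenyl carries no chloro, and a 1.4-fold higher number from compound 1 to compound 3 (0.14 log units; within the scatter) shows that phenyl and thiophen-2-yl cannot be told apart here either. No measurement shown offers an explanation for these small differences.

Chloro and hydrogen are only two possibilities at this position, so it remains open whether an amine or a carboxylic acid there would give a step beyond the scatter, or whether the position has little influence on this reading whatever group it carries. The rest of the shared core is identical in all three compounds, which leaves open whether a change elsewhere would shift these high numbers more than the changes on the carbonyl side have.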